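From 2-Methylcyclohexyl to 4-Methylcyclohexyl on an Amide Nitrogen

The source may hold more compounds than are shown below. What is called first, only, known or untested is meant among the compounds shown, and "the series" means these compounds.

Measured in a physicochemical assay for solubility, measured as thermodynamic solubility, with a stated time of 24 h, at pH 6.8; on this read-out lower numbers stand for lower solubility and higher numbers for higher solubility:
- compound 1 `Cc1cc(C)c2cc(C(=O)NC(C)C)[nH]c2c1`: 20000 nM
- compound 2 `Cc1cc(C)c2cc(C(=O)NC3CCCCCC3)[nH]c2c1`: < 4000 nM (a limit)
- compound 3 `C[C@H]1CCCC[C@H]1NC(=O)c1cc2c(Cl)cc(Cl)cc2[nH]1`: < 4000 nM (a limit)

For compound 3, then, no exact number is known, only a limit. Compound 2 shares that position: the limit of < 4000 nM in this assay, at which 2 of the 3 values shown sit.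

The next compound is compound 4 `CC1CCC(NC(=O)c2cc3c(Cl)cc(Cl)cc3[nH]2)CC1`. The change is 4-methylcyclohexyl in place of 2-methylcyclohexyl on an amide-type nitrogen. The two compounds have the same atoms, joined differently.

Going by the values given here, only one measured step offers a guide: an at least 5.0-fold lower number from compound 1 to compound 2 (0.69 log units; beyond the scatter), with cycloheptyl in place of isopropyl on an amide-type nitrogen. That swap replaces one group with a different one, whereas here the counts under comparison stay the same, so it bears only loosely on this case. No step beyond the usual scatter is expected in this assay, and another limit is quite likely.

The estimated value for compound 4 is 3000 nM, with an expected range from 1000 nM to 7000 nM.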

Compound 4, solubility: < 4000 nM
Compound 4: only a limit was reported (the forecaster's own chance of this, stated with the estimate: 80%); the middle value does not contradict the limit.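

Compound 3 and compound 4 are both reported only as limits in this assay, and no step between them can be read: the limit of < 4000 nM in this assay, at which 3 of the 4 values shown sit.

The compounds shown leave open whether 4-methylcyclohexyl and 2-methylcyclohexyl on an amide-type nitrogen give different numbers in this assay.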